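Notes on a ring methyl addition, compound 1 to compound 4

The source may report more compounds than this note shows. Statements on the series, on what has been measured and on what is new or still open speak of the compounds shown alone.

Of the compounds shown here, three have been measured in a functional assay on Bel-7402 cells (Homo sapiens) for antiproliferative activity, read by sulforhodamine B assay, tested at 100 ug/mL; a higher number here means more inhibition at the concentration tested (going by the name of the read-out), a lower number less inhibition. Compound 1 `Cc1ccc(NS(=O)(=O)C2CCCCC2=O)cc1` gives 27.5%. Compound 2 `Cc1cccc(NS(=O)(=O)C2CCCCC2=O)c1C` gives 21.8%, and compound 3 `COc1cc(OC)nc(NS(=O)(=O)C2CCCCC2=O)n1` gives 39.3%. Among these three numbers compound 1 stands second highest. Its nearest neighbour is compound 2, whose number sits within the usual scatter of the number for compound 1, so no order between these two can be read. Compound 3 lies furthest away, with a number beyond the scatter above that of compound 1. Going by the values given here, no pair among the three differs in one place only, so no single step has yet been measured.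

Compound 4 `Cc1ccc(NS(=O)(=O)C2CCCCC2=O)c(C)c1` has not been measured. It differs from compound 1 by methyl in place of hydrogen on an aromatic carbon. Among the compounds with values here, nothing measured speaks directly to this change; the only guidance is that compound 2, which also carries two methyl groups on its six-membered aromatic ring of carbon only, gives a number within the scatter of that of compound 1. The step from compound 1 to compound 4 in this assay is therefore expected to be small and in no clear direction, a number 2.5 percentage points lower from compound 1 to compound 4 (within the scatter), most likely not beyond the scatter. For compound 4 the estimate in this assay is 25%, with a range from 10% to 40%.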

Compound 4, a percentage reported as inhibition, at one concentration (the size of the read-out at that concentration, not a potency): 0.52%
The estimate for compound 4 lay 24.5 percentage points above the measured number; the measured number lies below the stated range.
By their numbers in this assay, from the lowest: compound 4; then compounds 2 and 1 (each within the scatter of the next); then compound 3.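

In this assay, going by these compounds alone, methyl in place of hydrogen on an aromatic carbon, ortho to a large group and meta to a methyl group, gives a number 27 percentage points lower from compound 1 to compound 4 (beyond the scatter) and provides the first single change that can be read. The step shows that this position is not neutral to substitution: one added heavy atom, with no ring, no hydrogen-bond donor or acceptor and no net charge, is enough to leave compound 4 at 0.52% in this read-out. No measurement in hand bears on why the number falls with this change at this position.

The compounds shown leave open whether the loss is specific to methyl or would also follow from another group on the same aromatic carbon, such as fluorine, a methoxy group, an amine or a longer chain. They also leave open whether removing the existing methyl group from compound 4 would change the number, and whether the step seen at this single concentration would hold at other concentrations.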